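Replacing the 2-(pyridin-2-yl)ethenyl group of compound 1

The compounds below may be only part of what the source reports. "The series", "measured", "known", "first", "only" and "open" are said of these compounds alone.

Measured so far in an ADME assay on BaF3 cells (Mus musculus) for antiproliferative activity, read by CCK-8 assay, with a stated time of 72 h; a lower number here means a stronger inhibitor of growth, a higher number a weaker inhibitor of growth:
- compound 1 `CN1CCN(Cc2ccc(NC(=O)CCSc3ccc4c(/C=C/c5ccccn5)n[nH]c4c3)cc2C(F)(F)F)CC1`: 2480 nM
- compound 2 `CC1CCN(Cc2ccc(NC(=O)CCSc3ccc4c(/C=C/c5ccccn5)n[nH]c4c3)cc2C(F)(F)F)CC1`: 4170 nM

Compound 1 gives 2480 nM and compound 2 gives 4170 nM. These two values lie within the scatter of each other, so neither compound can be ranked ahead. Compound 3 `Cc1ccc(-c2n[nH]c3cc(SCCC(=O)Nc4ccc(CN5CCN(C)CC5)c(C(F)(F)F)c4)ccc23)cn1` has not yet been measured. It keeps the rest of compound 1 and changes one group: 6-methylpyridin-3-yl in place of 2-(pyridin-2-yl)ethenyl on an aromatic carbon.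

Among the measured compounds shown here, only one measured step exists, a 1.7-fold higher number from compound 1 to compound 2 (0.23 log units; within the scatter). It puts 4-methylpiperidin-1-yl in place of 4-methylpiperazin-1-yl and stays within the scatter. That step touches a different group, so no measurement bears directly on the new change. The data give no direction for it, and no step beyond the scatter is expected in this assay. The estimated step is a 1.1-fold higher number from compound 1 to compound 3 (0.05 log units; within the scatter). For compound 3 the expected value is 2800 nM, with an estimated range of 700 nM to 10000 nM.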

Compound 3, concentration for 50% growth inhibition: 1180 nM
For compound 3 the middle estimate is 2.4-fold (0.38 log units) above the measured one, within the range that was stated.
By their numbers in this assay, from the lowest: compound 3; then compounds 1 and 2 (each within the scatter of the next).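

In this assay, the change on the aromatic carbon of the five-membered aromatic ring gives a 2.1-fold lower number from compound 1 to compound 3 (0.32 log units; beyond the scatter), a modest step, but the first one here to lie beyond the scatter. Among the compounds shown here, the earlier pair altered only the 4-methylpiperazin-1-yl group, so this is the first sign that the number responds to what sits at this position. It also shows that the 2-(pyridin-2-yl)ethenyl group, with its double bond outside aromatic rings, can give way to a directly attached 6-methylpyridin-3-yl group, one heavy atom smaller, with no loss of growth inhibition; no supporting evidence is available to explain the shift.

This single swap changes the double bond, the point of attachment on the pyridine ring and the methyl group all at once, so the compounds shown cannot say which of these matters. An unsubstituted pyridin-3-yl group or a 6-methoxypyridin-3-yl group at this position would help separate these effects, and pairing 6-methylpyridin-3-yl with 4-methylpiperidin-1-yl would test whether the two changes act independently.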